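A few compounds are considered here, and "the series" means these few. Any claim that something is new, unique, unknown or untested is made for them only; others in the source may bear on it.

Measured compounds in an ADME assay on HFL1 cells (Homo sapiens) for inhibition, read by MTT assay, with a stated time of 48 h; a lower number here means a stronger inhibitor, a higher number a weaker inhibitor:
compound 1, `COc1cc2ccc(=O)oc2cc1OC(=O)c1c(C)noc1-c1ccc(Cl)cc1`: 42200 nM
compound 2, `COc1cc2ccc(=O)oc2cc1OC(=O)c1c(C)noc1-c1ccccc1`: 69300 nM

Among the measured compounds shown here, compound 2 shows the highest number of the two in this assay, and its only neighbour is compound 1. The step of a 1.6-fold higher number from compound 1 to compound 2 (0.22 log units; within the scatter) lies within the scatter, so the two compounds cannot be ordered against each other on these numbers.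

Compound 3, `COc1cc2ccc(=O)oc2cc1OC(=O)c1c(C)noc1-c1ccc([N+](=O)[O-])cc1`, is not yet measured in this assay. It differs from compound 2 by nitro in place of hydrogen on an aromatic carbon. For the measured compounds named here, the one measured step that bears on a substituent at this carbon of the phenyl group is a 1.6-fold higher number from compound 1 to compound 2 (0.22 log units; within the scatter), and it stays within the scatter. No other substituent at that carbon has been tested in the series, so the data give no indication of a direction for the nitro group beyond what the chloro-to-hydrogen comparison shows.

The expected step is therefore a 1.3-fold lower number from compound 2 to compound 3 (0.10 log units; within the scatter), kept small because a 1.6-fold higher number from compound 1 to compound 2 (0.22 log units; within the scatter) was within the scatter. For compound 3 the estimated value in this assay is 55000 nM, with a range from 20000 nM to 150000 nM.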

Compound 3, half-maximal inhibitory concentration: 90900 nM
Compound 3: the middle estimate sits 1.7-fold (0.22 log units) below what was measured; the range from low to high includes it.
By their numbers in this assay, from the lowest: compounds 1, 2 and 3 (each within the scatter of the next, the first and the last beyond it).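

In this assay, among the compounds shown here, the nitro-for-chloro exchange gives the first step to lie beyond the scatter (a 2.2-fold higher number from compound 1 to compound 3 (0.33 log units; beyond the scatter)), so the substituent on this carbon, para to a large group, can shift the number, though only modestly. The exchange of hydrogen for nitro stays within the scatter (a 1.3-fold higher number from compound 2 to compound 3 (0.12 log units; within the scatter)), as does the chloro-to-hydrogen step, so the unsubstituted phenyl compound 2 cannot be separated from either substituted compound. Only the two substituted compounds, compound 1 and compound 3, can therefore be ordered, and the series supports no ranking of all three members or any trend across them. No evidence on the origin of the gap between compound 1 and compound 3 is available.

Still open, as far as these compounds go, is whether a substituent such as an amine, a carboxylic acid or a methoxy group at this same carbon would extend the modest spread or fall within it. From the compounds shown here alone, it is also open whether a chloro or nitro group at another carbon of the phenyl ring would give a step of similar size in this assay.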